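Pyrrolidinyl for dimethylamino on the aryl ring

A few compounds are considered here, and "the series" means these few. Any claim that something is new, unique, unknown or untested is made for them only; others in the source may bear on it.

Measured compounds:
compound 1 `OC1CNCc2nc(-c3ccc(N4CCCC4)cc3)sc21` — 140 nM
compound 2 `CN(C)c1ccc(-c2nc3c(s2)C(O)CNC3)c(CO)c1` — 22 nM

In a functional assay on MDA-MB-361 cells (Homo sapiens) for cytotoxicity, read by sulforhodamine B assay, with a stated time of 2 days (a lower number here means a stronger inhibitor, a higher number a weaker inhibitor), compound 2 gives 22 nM, the lowest of the two numbers, and compound 1 gives 140 nM, a gap that lies beyond the usual scatter. Compound 1 and compound 2 differ in more than one place, so their two values alone do not single out what that gap rests on.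

Compound 3 `OCc1cc(N2CCCC2)ccc1-c1nc2c(s1)C(O)CNC2` is not yet measured. It differs from compound 2 in one place: pyrrolidin-1-yl in place of dimethylamino on an aromatic carbon, on an aromatic carbon of a six-membered aromatic ring of carbon only, meta to a hydroxymethyl group and para to a large group. Compound 1 already carries pyrrolidin-1-yl and is the weaker of the two, but without a matched pair the change alone cannot be assigned a size. A step of modest size in either direction, or none beyond the scatter, is expected. Compound 3 is estimated at 28 nM, within 9 nM to 90 nM, which would mean an expected step of a 1.3-fold higher number from compound 2 to compound 3 (0.10 log units; within the scatter).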

Compound 3, half-maximal inhibitory concentration: 20 nM
Beside the measured number, compound 3's estimate is 1.4-fold (0.15 log units) above it; the range from low to high includes it.
By their numbers in this assay, from the lowest: compounds 3 and 2 (each within the scatter of the next); then compound 1.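

With pyrrolidin-1-yl in place of dimethylamino on this aromatic carbon, this assay shows a 1.1-fold lower number from compound 2 to compound 3 (0.04 log units; within the scatter) and so cannot tell the two groups apart, even though the entering group is a five-membered ring. Hydroxymethyl in place of hydrogen on an aromatic carbon, the single change separating these two compounds, gives a 7.0-fold lower number from compound 1 to compound 3 (0.85 log units; beyond the scatter) and is the only one of the two changes whose step lies beyond the scatter. Nothing measured here explains the size of either step.

The compounds shown leave open whether this position would also accept a piperidin-1-yl or morpholin-4-yl group, or a plain amino group. They also leave open whether a methoxy group or a carboxylic acid in place of the hydroxymethyl group would give a step of similar size.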